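The source may hold more compounds than are shown below. What is called first, only, known or untested is meant among the compounds shown, and "the series" means these compounds.

Measured compounds:
compound 1, `CCCCCCCC/C=C\CCCCCCCC(=O)OC[C@@H](C)OP(=O)(O)OC[C@H](N)C(=O)O`, in an assay on HEK293 cells for agonist activity at probable G-protein coupled receptor 34 (Mus musculus), with a stated time of 1 h (a higher number here means a larger maximal response, a lower number a smaller maximal response), compound 1 gives 12.8%.
compound 2, `CCCCCCCC/C=C\CCCCCCCC(=O)OC[C@@H](COCC)OP(=O)(O)OC[C@H](N)C(=O)O`, in this assay compound 2 gives 12.3%.

Compound 2 stands with compound 1 on these two numbers, the step of a number 0.5 percentage points lower from compound 1 to compound 2 (within the scatter) lying within the usual scatter, so the two values cannot be told apart.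

Compound 3, `CCCCCCCC/C=C\CCCCCCCC(=O)OC[C@@H](COCCC)OP(=O)(O)OC[C@H](N)C(=O)O`, has not yet been measured. It differs from compound 2 by methyl in place of hydrogen on a saturated chain carbon, two bonds along the chain from an oxygen on a saturated carbon, which lengthens the ethoxy of compound 2 to a propoxy.

For the measured compounds named here, the only measured step that bears on this change is a number 0.5 percentage points lower from compound 1 to compound 2 (within the scatter), where ethoxy in place of hydrogen at the neighbouring position left the maximal response unchanged within the scatter. Extending that ethoxy by one methyl is therefore expected to give a step of about a number 0.2 percentage points higher from compound 2 to compound 3 (within the scatter), no change beyond the scatter. For compound 3 the expected value in this assay is 12.5%, in the range 6% to 19%.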

Compound 3, largest response reached (Emax), in percent of the reference or control that the assay uses: 12.2%
Compound 3: the middle estimate sits 0.3 percentage points above what was measured; the range from low to high includes it.
By their numbers in this assay, from the lowest: compounds 3, 2 and 1 (each within the scatter of the next).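

In this assay, going one methyl further along the chain, from ethoxy to propoxy, gives a number 0.1 percentage points lower from compound 2 to compound 3 (within the scatter), so a second length of ether at this place also leaves the maximal response unchanged. Taking the propoxy directly in place of hydrogen gives a number 0.6 percentage points lower from compound 1 to compound 3 (within the scatter), which extends what the earlier pair showed for ethoxy alone: across hydrogen, ethoxy and propoxy, the three values cannot be told apart. No measurement available here accounts for this lack of change.

Going by these compounds, it remains open whether a longer chain such as a hexyloxy, or a chain ending in an amine or a carboxylic acid, would move the maximal response at this place. On these data alone, whether a phenyl ring there would separate from these three compounds is equally open.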